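Thiophene in Place of Methylphenyl: Antiproliferative Expectation

The compounds below may be only part of what the source reports. "The series", "measured", "known", "first", "only" and "open" are said of these compounds alone.

Compound 3 `Cc1ccc(-c2nc3c(c(-c4ccccc4)nn3-c3ccccc3)c(-c3ccc(O)cc3)c2C#N)cc1` stands lowest of the three numbers available in a functional assay on CCRF-CEM cells (Homo sapiens) for antiproliferative activity, read by resazurin assay, with a stated time of 72 h (a lower number here means a stronger inhibitor, a higher number a weaker inhibitor), where compound 3 gives 13400 nM. Compound 1 `N#Cc1c(-c2ccco2)nc2c(c(-c3ccccc3)nn2-c2ccccc2)c1-c1ccc(O)cc1` gives 23900 nM in this assay, and compound 2 `COc1cc(-c2c(C#N)c(-c3ccco3)nc3c2c(-c2ccccc2)nn3-c2ccccc2)ccc1O` gives 36500 nM. The step of a 1.5-fold higher number from compound 1 to compound 2 (0.18 log units; within the scatter) came with a methoxy in place of hydrogen on an aromatic carbon, and the step of a 1.8-fold lower number from compound 1 to compound 3 (0.25 log units; within the scatter) came with 4-methylphenyl in place of furan-2-yl on an aromatic carbon. Compound 4 `N#Cc1c(-c2cccs2)nc2c(c(-c3ccccc3)nn2-c2ccccc2)c1-c1ccc(O)cc1` carries thiophen-2-yl in place of 4-methylphenyl on an aromatic carbon. The step from compound 1 to compound 3 bears most directly on this change, since it exchanged the same 4-methylphenyl group against furan-2-yl, a ring that resembles the thiophen-2-yl now entering, and that step stayed within the scatter. The other step, from compound 1 to compound 2, also stayed within the scatter. Compound 4 is therefore expected to show a 1.3-fold higher number from compound 3 to compound 4 (0.13 log units; within the scatter) in this assay, nothing beyond the scatter. The estimate for compound 4 in this assay is 18000 nM, within a range from 8000 nM to 40000 nM.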

Compound 4, half-maximal inhibitory concentration: > 25000 nM
Compound 4: no number, only a limit; the forecaster's own chance of this, stated with the estimate: 5%; middle value at least 1.3-fold (0.14 log units) from the limit.
By their numbers in this assay, from the lowest: compounds 3, 1 and 2 (each within the scatter of the next, the first and the last beyond it).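

In this assay compound 4 gives > 25000 nM, which is a limit of the assay and not a number. On the aromatic carbon next to the ring nitrogen, thiophen-2-yl brings an at least 1.8-fold higher number from compound 3 to compound 4 (0.27 log units; that floor lies within the scatter) against 4-methylphenyl and an at least 1.0-fold higher number from compound 1 to compound 4 (0.01 log units; that floor lies within the scatter) against furan-2-yl, so it lowers the number against neither ring, although both steps are only floors and neither shows a real difference beyond the scatter. Compound 4 is the only compound shown whose reading ends in a limit: the limit of > 25000 nM in this assay, at which 1 of the 4 values shown sits.

On these data alone, how far beyond its limit compound 4 lies stays open, and with it whether thiophen-2-yl truly differs from furan-2-yl or 4-methylphenyl here. Also open, as far as these compounds go, is whether an amine, a carboxylic acid or a longer chain at this position would move the number beyond the scatter.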